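Swapping a naphthalene for a methylphenyl group

This account rests on a few compounds, and the source may have more. Where it says the series, first, only, none or still open, it means among the compounds named here.

Measured in a functional assay on HeLa cells (Homo sapiens) for antiproliferative activity, with a stated time of 5 days; a lower number here means a stronger inhibitor, a higher number a weaker inhibitor:
Compound 1 `CC1OC2(C=CC(=O)C=C2)N(c2nc(-c3ccc4ccccc4c3)nn2-c2ccc3ccccc3c2)C1=O`: 300 nM
Compound 2 `Cc1ccccc1-n1nc(-c2cccc3ccccc23)nc1N1C(=O)COC12C=CC(=O)C=C2`: 100 nM
Compound 3 `O=C1C=CC2(C=C1)OCC(=O)N2c1nc(-c2ccc(F)c3ccccc23)nn1-c1ccccc1`: 200 nM

Compound 1, at 300 nM, has the highest of the three numbers, which makes it the weakest on paper only against compound 2. Its gap to compound 3 lies within the scatter, while its gap to compound 2 lies beyond it.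

Compound 4 `Cc1ccc(-n2nc(-c3ccc4ccccc4c3)nc2N2C(=O)C(C)OC23C=CC(=O)C=C3)cc1` keeps the rest of compound 1 and has 4-methylphenyl in place of naphthalen-2-yl on an aromatic nitrogen. Among the measured compounds shown here, no measured pair shows this change alone, so the guide is indirect. Compound 2, at 100 nM, and compound 3, at 200 nM, also carry a single six-membered aromatic ring on that nitrogen, though they differ elsewhere too. A small move toward a lower number in this assay therefore seems likely, not expected to go beyond the scatter. The expected step is a 1.5-fold lower number from compound 1 to compound 4 (0.18 log units; within the scatter). For compound 4 the estimated value is 200 nM, with an expected range from 80 nM to 500 nM.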

Compound 4, half-maximal inhibitory concentration: 530 nM
Compound 4: the middle estimate sits 2.7-fold (0.42 log units) below what was measured; the measured number lies above the stated range.
By their numbers in this assay, from the lowest: compounds 2, 3, 1 and 4 (each within the scatter of the next, the first and the last beyond it).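

In this assay, putting 4-methylphenyl in place of naphthalen-2-yl on the aromatic nitrogen gives a 1.8-fold higher number from compound 1 to compound 4 (0.25 log units; within the scatter). Among the compounds shown here, this is the first reading of that change on its own: with one six-membered aromatic ring of carbon in place of two, and fewer heavy atoms, the compound stays in the same range of activity. Nothing measured here gives a reason for this result.

Still open, on these data alone, is how this aromatic nitrogen would respond to a group carrying other atoms, such as a pyridine ring, or a phenyl ring bearing an amine or a carboxylic acid. Also open, as far as these compounds go, is whether the change would read the same with the other groups found in compound 2 and compound 3, which differ from compound 1 in more than one place.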